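This account rests on a few compounds, and the source may have more. Where it says the series, first, only, none or still open, it means among the compounds named here.

Compound 1 `COc1ccc(-c2cc3nccc(-c4cc(OC)c(OC)c(OC)c4)n3n2)cc1N` — 27 nM in a functional assay on MCF7 cells (Homo sapiens) for inhibition, read by CCK-8 assay, with a stated time of 48 h; a lower number here means a stronger inhibitor, a higher number a weaker inhibitor
Compound 2 `COc1cc(-c2ccnc3c(-c4ccc(C)cc4)cnn23)cc(OC)c1OC` — > 10000 nM in this assay, a limit rather than a number

For the measured compounds named here, compound 1 stands as the only numeric value in this assay. Compound 2 sits at the assay limit, as the limit of > 10000 nM in this assay, at which 1 of the 2 values shown sits, shows. Compound 3 `COc1cc(-c2ccnc3cc(-c4c[nH]c5ccccc45)nn23)cc(OC)c1OC` differs from compound 1 by 1H-indol-3-yl in place of 3-amino-4-methoxyphenyl on an aromatic carbon. Going by the values given here, no step between measured compounds bears on this change, so the expectation rests on compound 1 alone. The step of a 7.4-fold higher number from compound 1 to compound 3 (0.87 log units; beyond the scatter) is expected to be a moderate loss, beyond the scatter. Compound 3 is therefore estimated at 200 nM in this assay, within 30 nM to 3000 nM.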

Compound 3, half-maximal inhibitory concentration: 85 nM
Beside the measured number, compound 3's estimate is 2.4-fold (0.37 log units) above it, within the range that was stated.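

At this aromatic carbon of the five-membered ring, 1H-indol-3-yl in place of 3-amino-4-methoxyphenyl gives a 3.1-fold higher number from compound 1 to compound 3 (0.50 log units; beyond the scatter) in this assay. The position therefore accepts a group with a quite different ring make-up at a modest cost, and compound 3 still reads as a number rather than a limit. Nothing shown here accounts for the size of this step.

The compounds shown leave open how a 3-aminophenyl or a 4-methoxyphenyl group would read at this position. The step therefore cannot be assigned to the amine or the methoxy of the group that leaves.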